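Ring size of the basic amine in the ether side chain

The source may hold more compounds than are shown below. What is called first, only, known or untested is meant among the compounds shown, and "the series" means these compounds.

Compound 3 `CC1=C(c2cccc(O)c2)C(c2ccc(OC[C@@H](C)N3CCCC3)cc2)Oc2ccc(O)cc21` stands level with compound 1 `CC1=C(c2cccc(O)c2)C(c2ccc(OC[C@H](C)N3CCCC3)cc2)Oc2ccc(O)cc21` and compound 2 `CC1=C(c2cccc(O)c2)C(c2ccc(OC[C@H](C)N3CC[C@H](C)C3)cc2)Oc2ccc(O)cc21` in a functional assay on MCF7 cells (Homo sapiens) for antiproliferative activity, read by CellTiter-Glo, with a stated time of 5 days; a higher number here means a weaker inhibitor, a lower number a stronger inhibitor. In this assay compound 1 gives 0.2 nM, compound 2 gives 0.2 nM and compound 3 gives 0.2 nM. The two measured steps touching the amine region are flat: no change at the digits printed from compound 1 to compound 2 (within the scatter) for methyl in place of hydrogen on a saturated ring carbon, and no change at the digits printed from compound 2 to compound 3 (within the scatter) for the smaller ring in place of the methyl-bearing one; no change at the digits printed from compound 1 to compound 3 (within the scatter) follows from the fact that one of compounds 1 and 3 is drawn with a defined configuration and the other without, at the place where they differ and is also flat.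

Compound 4 `CC1=C(c2cccc(O)c2)C(c2ccc(OC[C@H](C)N3CCCCCC3)cc2)Oc2ccc(O)cc21` carries the change (a group of 9 heavy atoms (8 carbon, 1 nitrogen; one seven-membered non-aromatic ring with 1 hetero atom) in place of a group of 7 heavy atoms (6 carbon, 1 nitrogen; one five-membered non-aromatic ring with 1 hetero atom), on a saturated chain carbon bound to an oxygen on an aromatic ring). The measured steps bear on this directly: the ring substituent on the saturated chain carbon bound to the oxygen on the aromatic ring has been varied twice without moving this assay, so a step of about a 1.5-fold higher number from compound 3 to compound 4 (0.18 log units; within the scatter) is expected, with no direction beyond the scatter. Compound 4 is therefore estimated at 0.3 nM, expected range 0.1 nM to 1 nM.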

Compound 4, half-maximal inhibitory concentration: 0.2 nM
The estimate for compound 4 lay 1.5-fold (0.18 log units) above the measured number; measured number inside the range.
By their numbers in this assay, from the lowest: compounds 1, 2, 3 and 4 (each within the scatter of the next).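

In this assay the ring on the saturated chain carbon now goes from five-membered to seven-membered: azepan-1-yl in place of pyrrolidin-1-yl gives a flat reading (no change at the digits printed from compound 1 to compound 4 (within the scatter)). Azepan-1-yl in place of 3-methylpyrrolidin-1-yl reads the same (no change at the digits printed from compound 2 to compound 4 (within the scatter)), as does the comparison with the opposite drawn configuration (no change at the digits printed from compound 3 to compound 4 (within the scatter)). The flat response thus extends from a ring methyl and the drawn configuration to ring size itself, and nothing on hand accounts for it.

Open, on these data alone, are the six-membered piperidin-1-yl, morpholin-4-yl with its second hetero atom in the ring, and an open-chain dimethylamino group. Also open, as far as these compounds go, is whether any amine at this place moves the number beyond the scatter in this assay.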